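Series notes: a dichlorophenyl variant of compound 2

The compounds below may be only part of what the source reports. "The series", "measured", "known", "first", "only" and "open" are said of these compounds alone.

The shared core is carried unchanged through compound 1 `N#CC1=C(N)Oc2c(N)cc3nc4ccccc4nc3c2C12C(=O)N(Cc1cnnn1-c1ccc(F)cc1)c1ccccc12`, compound 2 `N#CC1=C(N)Oc2c(N)cc3nc4ccccc4nc3c2C12C(=O)N(Cc1cnnn1-c1ccc([N+](=O)[O-])cc1)c1ccccc12` and the still unmeasured compound 3 `N#CC1=C(N)Oc2c(N)cc3nc4ccccc4nc3c2C12C(=O)N(Cc1cnnn1-c1cc(Cl)ccc1Cl)c1ccccc12`. In a functional assay on A549 cells (Homo sapiens) for antiproliferative activity, read by MTT assay, with a stated time of 48 h (on this read-out lower numbers stand for stronger inhibition and higher numbers for weaker inhibition), compound 1 gives only the assay limit > 50000 nM. In this assay compound 2 likewise returns only the limit > 50000 nM, so compound 2 stands at the limit and nowhere within the numbered range. Within the data shown here, the single measured step, a step that the two limits leave unreadable from compound 1 to compound 2, is accordingly of unreadable size. The change to compound 3 is 2,5-dichlorophenyl in place of 4-nitrophenyl on an aromatic nitrogen. Among the measured compounds shown here, no measured step bears directly on this change; the only evidence is the limit of > 50000 nM in this assay, at which 2 of the 2 values shown sit, where both values sit. Because of the limit of > 50000 nM in this assay, at which 2 of the 2 values shown sit, no step beyond the scatter can be read in either direction. Compound 3 is expected to give 70000 nM, in the range 20000 nM to 250000 nM, most probably again as a limit. The step this estimate means is a step that the limit leaves unreadable from compound 2 to compound 3, taken as no readable change.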

Compound 3, half-maximal inhibitory concentration: 10900 nM
For compound 3 the middle estimate is 6.4-fold (0.81 log units) above the measured one; the measured number lies below the stated range.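

In this assay, the group on the aromatic nitrogen of the five-membered ring can move the result off the limit: 2,5-dichlorophenyl in place of 4-nitrophenyl gives an at least 4.5-fold lower number from compound 2 to compound 3 (0.66 log units; beyond the scatter), and 2,5-dichlorophenyl in place of 4-fluorophenyl gives an at least 4.5-fold lower number from compound 1 to compound 3 (0.66 log units; beyond the scatter). Among the compounds shown, a numbered value in this read-out therefore appears only with the 2,5-dichlorophenyl group, which compound 1 and compound 2 alone could not reveal. Both steps are minimum sizes and the step between compound 1 and compound 2 cannot be read, for one reason: the limit of > 50000 nM in this assay, at which 2 of the 3 values shown sit.

As far as these compounds go, it remains open whether a single chlorine on the phenyl ring would give a numbered value, or whether both chlorines are required. From the compounds shown here alone, the outcome with an unsubstituted phenyl, a methoxyphenyl or a pyridyl group at this position is also open.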